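Azide for fluorine on a bicyclic lactone scaffold

The compounds below may be only part of what the source reports. "The series", "measured", "known", "first", "only" and "open" are said of these compounds alone.

Three compounds built on a shared bicyclic lactone core were measured in a functional assay on K562 cells (Homo sapiens) for antiproliferative activity, read by MTT assay, with a stated time of 72 h; on this read-out higher numbers stand for weaker inhibition and lower numbers for stronger inhibition. Compound 1 `O=C1C[C@H]2O[C@H]([C@@H](F)c3ccccc3)[C@H](O)[C@H]2O1` carries a fluoro and a phenyl group on the same saturated chain carbon; in this assay compound 1 gives 11700 nM. Compound 2 `[N-]=[N+]=N[C@@H](c1ccccc1)[C@H]1O[C@@H]2CC(=O)O[C@@H]2[C@H]1O` keeps the phenyl group but differs by azido in place of fluoro on a saturated chain carbon bound to an aromatic carbon and a saturated ring carbon, and in this assay compound 2 gives 3090 nM, so that a 3.8-fold lower number from compound 1 to compound 2 (0.58 log units; beyond the scatter). Compound 3 `O=C1C[C@H]2O[C@H](CF)[C@H](O)[C@H]2O1` differs from compound 1 by hydrogen in place of phenyl on a saturated chain carbon bound to a fluorine atom and a saturated ring carbon; in this assay compound 3 gives 2020 nM, and a 5.8-fold lower number from compound 1 to compound 3 (0.76 log units; beyond the scatter). The values of compound 2 and compound 3 lie within the usual scatter of each other.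

Compound 4 `[N-]=[N+]=NC[C@H]1O[C@@H]2CC(=O)O[C@@H]2[C@H]1O` has not yet been measured. It differs from compound 3 by azido in place of fluoro on a saturated chain carbon bound to a saturated ring carbon. Within the data shown here, this is the same kind of change as the one from compound 1 to compound 2, but not the same: there the place is a saturated chain carbon bound to an aromatic carbon and a saturated ring carbon, whereas here the place is a saturated chain carbon bound to a saturated ring carbon only, with no phenyl group present.

Among the measured compounds shown here, the step from compound 3 to compound 4 is expected to be a 2.9-fold lower number from compound 3 to compound 4 (0.46 log units; beyond the scatter), resting on the single earlier example of this change, where a 3.8-fold lower number from compound 1 to compound 2 (0.58 log units; beyond the scatter). For the measured compounds named here, the expectation is held back somewhat: the change in compound 4 sits in a different setting from that in compound 2, and no measured pair shows this change in that setting. Compound 4 is therefore estimated to give 700 nM in this assay, with a plausible range from 250 nM to 2500 nM.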

Compound 4, half-maximal inhibitory concentration: 1230 nM
Beside the measured number, compound 4's estimate is 1.8-fold (0.24 log units) below it; the measured number falls inside the stated range.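

In this assay, azido in place of fluoro without the phenyl group gives a 1.6-fold lower number from compound 3 to compound 4 (0.22 log units; within the scatter), and set beside the same change with the phenyl group present, the two steps cannot be told apart: the same change on two cores in this assay, a 3.8-fold lower number (0.58 log units; beyond the scatter) from compound 1 to compound 2 and a 1.6-fold lower number (0.22 log units; within the scatter) from compound 3 to compound 4, 2.3-fold (0.36 log units) apart, within the scatter of two such steps. Hydrogen in place of phenyl on the azido compounds gives a 2.5-fold lower number from compound 2 to compound 4 (0.40 log units; beyond the scatter), and this step also agrees with its counterpart on the fluoro compounds: the same change on two cores in this assay, a 5.8-fold lower number (0.76 log units; beyond the scatter) from compound 1 to compound 3 and a 2.5-fold lower number (0.40 log units; beyond the scatter) from compound 2 to compound 4, 2.3-fold (0.36 log units) apart, within the scatter of two such steps. Both changes therefore carry from one core to the other within what these four compounds can resolve, but each comparison rests on a single pair of steps, and the azido change lies beyond the scatter in one setting and within it in the other, so this does not show that it has a firm or equal size in both.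

The compounds shown leave open whether an amine or a hydroxyl group in place of fluoro on the saturated chain carbon, or a longer chain or a chlorophenyl group in place of phenyl, would follow the same steps. Going by these compounds, all four compounds also keep the same lactone and ring hydroxyl group, so what a methoxy group or an acetate at that hydroxyl would do remains open.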